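Adding Fluoro to the Phenyl Compound

The source may report more compounds than this note shows. Statements on the series, on what has been measured and on what is new or still open speak of the compounds shown alone.

In a functional assay on CAPAN-1 cells (Homo sapiens) for antiproliferative activity, with a stated time of 72 h (a lower number here means a stronger inhibitor, a higher number a weaker inhibitor), compound 1 `CCCCC#Cc1cc([C@@H]2O[C@H](CO)[C@@H](O)[C@H]2O)n2ncnc(N)c12` gives 1000 nM while compound 2 `Nc1ncnn2c([C@@H]3O[C@H](CO)[C@@H](O)[C@H]3O)cc(C#Cc3cccs3)c12` gives 32000 nM on the same core. Compound 3 `Nc1ncnn2c([C@@H]3O[C@H](CO)[C@@H](O)[C@H]3O)cc(-c3ccccc3)c12` gives 65200 nM as the highest number of the three, which makes it the weakest inhibitor so far. Compound 4 `Nc1ncnn2c([C@@H]3O[C@H](CO)[C@@H](O)[C@H]3O)cc(-c3ccc(F)cc3)c12` differs from compound 3 by fluoro in place of hydrogen on an aromatic carbon in one place: fluoro in place of hydrogen on an aromatic carbon, para to a large group.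

Within the data shown here, no measured step makes this change. The steps that remove the butyl chain were large, at a 32-fold higher number from compound 1 to compound 2 (1.51 log units; beyond the scatter) and a 65-fold higher number from compound 1 to compound 3 (1.81 log units; beyond the scatter) alike. The closest guide is the step with an aromatic ring on both sides, a 2.0-fold higher number from compound 2 to compound 3 (0.31 log units; beyond the scatter), which was modest even though a whole group was exchanged. A smaller change is therefore expected to move the number less, with no firm direction in this assay and nothing beyond the scatter. The expected step is a 1.3-fold lower number from compound 3 to compound 4 (0.12 log units; within the scatter) and would lie within the usual scatter. For compound 4 the estimated value is 50000 nM as a middle, with 20000 nM and 100000 nM as the expected lower and upper ends.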

Compound 4, half-maximal inhibitory concentration: 65600 nM
Compound 4: the middle estimate sits 1.3-fold (0.12 log units) below what was measured, and the stated range covers the measured number.
By their numbers in this assay, from the lowest: compound 1; then compound 2; then compounds 3 and 4 (each within the scatter of the next).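

In this assay, fluoro in place of hydrogen on the aromatic carbon para to a large group leaves the number unmoved, with a 1.0-fold higher number from compound 3 to compound 4 (0.00 log units; within the scatter), so this one atom does not separate the two compounds. The 4-fluorophenyl group also stands about as far from the alkynyl groups as phenyl did, with a 2.1-fold higher number from compound 2 to compound 4 (0.31 log units; beyond the scatter) and a 66-fold higher number from compound 1 to compound 4 (1.82 log units; beyond the scatter). The large gap to the hex-1-yn-1-yl group therefore survives the addition of fluoro.

Still open, on these data alone, is whether an amine or a carboxylic acid at this same place on the ring would move the number, and whether a longer chain on the triple bond would bring a further gain. Nothing available gives any reason for the absence of change with fluoro.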